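A few compounds are considered here, and "the series" means these few. Any claim that something is new, unique, unknown or untested is made for them only; others in the source may bear on it.

Measured compounds in a functional assay on DLD-1 cells (Homo sapiens) for antiproliferative activity, read by CellTiter-Glo, with a stated time of 72 h; a higher number here means a weaker inhibitor, a lower number a stronger inhibitor:
- compound 1 `CC1CCN(C2CCN(S(=O)(=O)c3ccc(C#N)cc3)CC2)CC1` gives 2800 nM
- compound 2 `CC1CCN(C2CCN(S(=O)(=O)c3cccc(N)c3)CC2)CC1` gives 3400 nM
- compound 3 `COc1cccc(S(=O)(=O)N2CCC(N3CCC(C)CC3)CC2)c1` gives only a limit of the assay, > 5000 nM

The three compounds share one core and differ only in the aryl group on the sulfonyl sulfur. Compound 3 stands at the edge of what the assay resolves: its value is one of those sitting at the limit of > 5000 nM in this assay, at which 1 of the 3 values shown sits, so no number is known for it, and its distance from the other two can be given as a floor only. The steps among the measured compounds are a 1.2-fold higher number from compound 1 to compound 2 (0.08 log units; within the scatter), an at least 1.7-fold higher number from compound 1 to compound 3 (0.25 log units; that floor lies within the scatter) and an at least 1.4-fold higher number from compound 2 to compound 3 (0.16 log units; that floor lies within the scatter); none of them lies beyond the scatter.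

Compound 4 `CC1CCN(C2CCN(S(=O)(=O)c3cn(C)cn3)CC2)CC1` differs from compound 3 by 1-methyl-1H-imidazol-4-yl in place of 3-methoxyphenyl on a sulfonyl sulfur. The three measured steps all exchange one aryl group on the same sulfonyl sulfur, and none of them moved the number beyond the scatter, so no step beyond the scatter is expected in this assay here either, in either direction, which is a step that the limit leaves unreadable from compound 3 to compound 4. Since compound 3 has no number of its own, the estimate for compound 4 is necessarily broad and there is a fair chance that the assay again returns only a limit. The expected value for compound 4 in this assay is 6000 nM, with a range of 2500 nM to 20000 nM.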

Compound 4, half-maximal inhibitory concentration: > 5000 nM
Compound 4 was reported as a limit (the forecaster's own chance of this, stated with the estimate: 55%); the middle value does not contradict the limit.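

In this assay compound 4 gives > 5000 nM, which is a limit of the assay and not a number. 1-Methyl-1H-imidazol-4-yl is the only group shown on the sulfonyl sulfur with a five-membered aromatic ring with hetero atoms rather than a six-membered aromatic ring of carbon only, and the two readable steps are an at least 1.4-fold higher number from compound 2 to compound 4 (0.16 log units; that floor lies within the scatter) and an at least 1.7-fold higher number from compound 1 to compound 4 (0.25 log units; that floor lies within the scatter), so this change of ring type brings no step beyond the scatter that can be read. The step between compound 3 and compound 4 cannot be read, and the series now reaches the end of the readable range with two different groups at this position: the limit of > 5000 nM in this assay, at which 2 of the 4 values shown sit.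

As far as these compounds go, how far compound 3 and compound 4 actually lie past the limit stays open, and so does whether any change of the aryl group at this position can move the number beyond the scatter in either direction. Also open, from the compounds shown here alone, is how a carboxylic acid, an amine or a simple cyclopropyl group on the sulfonyl sulfur would read in this assay.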